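The source may report more compounds than this note shows. Statements on the series, on what has been measured and on what is new or still open speak of the compounds shown alone.

Compound 1, with the structure `Cc1c(OCCCCOc2ccccc2C(=O)O)ccc(C(=O)CC(C)C)c1O`, is the starting point here. Going by the values given here, in an assay on HEK293 cells for positive allosteric modulation of metabotropic glutamate receptor 3 (Rattus norvegicus), read by thallium flux, with a stated time of 2.5 min (a lower number here means a smaller maximal response, a higher number a larger maximal response), compound 1 gives 28.1%, the lowest of the three numbers so far, though its two neighbours sit close: compound 2, `Cc1c(OCCCCOc2ccccc2C(=O)O)ccc(C(=O)CC2CCCC2)c1O`, gives 32.9%, and compound 3, `Cc1c(OCCCCOc2ccccc2C(=O)O)ccc(C(=O)CC(C)C)c1C`, gives 30.7%. The step of a number 4.8 percentage points higher from compound 1 to compound 2 (within the scatter) came from putting cyclopentyl in place of isopropyl on a saturated chain carbon bound to a carbonyl carbon, and the step of a number 2.6 percentage points higher from compound 1 to compound 3 (within the scatter) from putting methyl in place of hydroxy on an aromatic carbon; both stay within the scatter, so all three compounds behave much alike in this assay.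

Compound 4, with the structure `Cc1cc(C(=O)O)ccc1OCCCCOc1ccc(C(=O)CC(C)C)c(O)c1C`, has not yet been measured. It differs from compound 1 at the far end of the chain: 4-carboxy-2-methylphenyl in place of 2-carboxyphenyl on an oxygen on a saturated carbon. Neither measured step touches this part of the molecule, so there is no direct guide to its effect. The two steps that are known were both small, and nothing in them points to a large movement from one aryl group to another. The expected change is therefore a number 1.9 percentage points higher from compound 1 to compound 4 (within the scatter), no step beyond the scatter. For compound 4 the estimated value in this assay is 30%, within a range from 15% to 45%.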

Compound 4, largest response reached (reported as percent of maximum), in percent of the reference or control that the assay uses: 42.1%
Beside the measured number, compound 4's estimate is 12.1 percentage points below it; the measured number falls inside the stated range.
By their numbers in this assay, from the lowest: compounds 1, 3, 2 and 4 (each within the scatter of the next, the first and the last beyond it).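

In this assay, putting 4-carboxy-2-methylphenyl in place of 2-carboxyphenyl on the oxygen at the end of the saturated chain gives a number 14 percentage points higher from compound 1 to compound 4 (beyond the scatter), the only step shown that clears the scatter. The two changes at other places in the molecule, cyclopentyl for isopropyl and methyl for hydroxy, both stayed within the scatter, so among these compounds only the aryl group on this oxygen has moved the maximal response by a clear margin. This single swap both adds a methyl and changes where the carboxy group sits on the ring, and no measurement shown explains the higher response or assigns it to either difference.

The compounds shown leave open how much of the step would remain with 4-carboxyphenyl, which carries no methyl, and whether a tetrazole could stand in for the carboxylic acid on this ring. As far as these compounds go, it is also open whether the new aryl group would combine with cyclopentyl at the other end of the molecule, or how a longer chain would alter the response.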